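A few compounds are considered here, and "the series" means these few. Any claim that something is new, unique, unknown or untested is made for them only; others in the source may bear on it.

Series notes. Compound 1 `CCCCN(CCC)c1nc(C)nc2c(-c3ccc(OC)nc3C)c(C)nn12` gives 2.4 nM in an assay on cell membranes for displacement of a labelled ligand from corticotropin-releasing factor receptor 1 (Rattus norvegicus) (on this read-out lower numbers stand for stronger inhibition and higher numbers for weaker inhibition), the lowest of the two numbers recorded so far. Compound 2 `CCN(CC)c1nc(C)nc2c(-c3cnc(OC)cc3C)c(C)nn12` gives 14.5 nM in this assay, and the gap between compound 2 and compound 1 lies beyond the scatter. Compound 3 `CCCC(C)Nc1nc(C)nc2c(-c3ccc(OC)nc3C)c(C)nn12` is still to be measured. It differs from compound 1 by (1-methylbutyl)amino in place of butyl(propyl)amino on an aromatic carbon. Among the measured compounds shown here, no step between measured compounds isolates this change, so the expectation rests on compound 1 alone. A modest weakening is expected, the step of a 2.1-fold higher number from compound 1 to compound 3 (0.32 log units; beyond the scatter) probably falling near the edge of the scatter. Compound 3 is expected at 5 nM, within 1.5 nM to 16 nM.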

Compound 3, half-maximal inhibitory concentration: 3.5 nM
For compound 3 the middle estimate is 1.4-fold (0.15 log units) above the measured one, and the stated range covers the measured number.
By their numbers in this assay, from the lowest: compounds 1 and 3 (each within the scatter of the next); then compound 2.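

In this assay, (1-methylbutyl)amino in place of butyl(propyl)amino on this aromatic carbon gives a 1.5-fold higher number from compound 1 to compound 3 (0.16 log units; within the scatter), so the two amino groups cannot be told apart on this read-out. The entering group has fewer heavy atoms and carries a hydrogen-bond donor that butyl(propyl)amino lacks, yet neither difference separates the two compounds here. No measurement available explains why the two groups read alike. Still open, going by these compounds, is whether a ring amine such as morpholine, or a much shorter chain such as methylamino, would also stay within the scatter of compound 1.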